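The compounds below may be only part of what the source reports. "The series", "measured", "known", "first", "only" and "open" are said of these compounds alone.

Working notes on the series in a functional assay on MIA PaCa-2 cells (Homo sapiens) for cytotoxicity, read by MTT assay, with a stated time of 72 h; on this read-out higher numbers stand for weaker inhibition and lower numbers for stronger inhibition: compound 1 (`COC1=CC(=O)c2c(c(COc3ccccc3)c(C)n2C)C1=O`) gives 962 nM, compound 2 (`COC1=CC(=O)c2c(c(COc3ccccc3[N+](=O)[O-])c(C)n2C)C1=O`) gives 104 nM, and compound 3 (`COC1=CC(=O)c2c(c(COc3cccnc3)c(C)n2C)C1=O`) gives 562 nM. Compound 3 lies within the scatter of compound 1, while compound 2 has a number lower than both, beyond the scatter. Compound 4 (`COC1=CC(=O)c2c(c(COc3ccncc3)c(C)n2C)C1=O`) has the same atoms as compound 3, joined differently: pyridin-4-yl in place of pyridin-3-yl on an oxygen on a saturated carbon, with pyridin-4-yl in place of pyridin-3-yl on an oxygen on a saturated carbon. The closest evidence is the change from phenyl to pyridin-3-yl, a 1.7-fold lower number from compound 1 to compound 3 (0.23 log units; within the scatter), which stays within the scatter. The nitro step, a 9.3-fold lower number from compound 1 to compound 2 (0.97 log units; beyond the scatter), is larger, but compound 4 carries no nitro group. Among the compounds with values here, no measured step compares the two pyridinyl groups directly, so no step beyond the scatter is expected in this assay, and no direction is favoured. The expected change is a 1.1-fold lower number from compound 3 to compound 4 (0.05 log units; within the scatter). For compound 4 the estimated value is 500 nM, with an expected range of 200 nM to 1200 nM.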

Compound 4, half-maximal inhibitory concentration: 2170 nM
Compound 4: middle estimate off by 4.3-fold (0.64 log units), on the low side; the whole stated range lies below it.
By their numbers in this assay, from the lowest: compound 2; then compounds 3 and 1 (each within the scatter of the next); then compound 4.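

At this place, on an oxygen on a saturated carbon, the two pyridinyl groups do not behave alike in this assay: pyridin-4-yl in place of pyridin-3-yl gives a 3.9-fold higher number from compound 3 to compound 4 (0.59 log units; beyond the scatter). Pyridin-4-yl in place of phenyl also gives a step beyond the scatter, a 2.3-fold higher number from compound 1 to compound 4 (0.35 log units; beyond the scatter), which the pyridin-3-yl step did not. Nothing available explains the difference. Open, as far as these compounds go, is how a pyridin-2-yl group would compare at this place. Also open, from the compounds shown here alone, is whether an amine or a carboxylic acid in place of hydrogen on the phenyl ring would match the nitro step.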